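The source may hold more compounds than are shown below. What is called first, only, known or untested is meant among the compounds shown, and "the series" means these compounds.

The measured compounds:

Compound 1, `Fc1ccc(Cn2cc(CSC(=S)N3CCNCC3)nn2)cc1`, in a functional assay on ECa-109 cells (Homo sapiens) for inhibition, read by MTT assay, with a stated time of 72 h (on this read-out lower numbers stand for stronger inhibition and higher numbers for weaker inhibition), gives > 128000 nM, which is a limit of the assay and not a number.
Compound 2, `S=C(SCc1cn(Cc2ccccc2Cl)nn1)N1CCNCC1`, in this assay gives > 128000 nM, likewise a limit of the assay.
Compound 3, `S=C(SCc1cn(Cc2ccc(Cl)c(Cl)c2)nn1)N1CCNCC1`, in this assay gives > 128000 nM, also a limit of the assay.

Compound 3 therefore stands only at a limit in this assay, and the same holds for the two other measured compounds, all of which sit at the limit of > 128000 nM in this assay, at which 3 of the 3 values shown sit. The three steps among them, a step that the two limits leave unreadable from compound 1 to compound 2, a step that the two limits leave unreadable from compound 1 to compound 3 and a step that the two limits leave unreadable from compound 2 to compound 3, each exchange the aryl group on the saturated chain carbon bound to the aromatic nitrogen, and none of them can be read, since both ends sit at the limit.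

Compound 4, `Cc1ccc(Cn2cc(CSC(=S)N3CCNCC3)nn2)cc1`, has not yet been measured in this assay. It differs from compound 3 by 4-methylphenyl in place of 3,4-dichlorophenyl on a saturated chain carbon bound to an aromatic nitrogen. All three measured steps bear on this change, as each swaps the aryl group at the same place, yet none gives a readable size. There is thus no basis for expecting a step beyond the scatter in either direction, and the expectation is that compound 4 will also be reported at the limit. The estimated step is a step that the limit leaves unreadable from compound 3 to compound 4. Compound 4 is accordingly expected to give about 150000 nM, with a range from 60000 nM to 500000 nM.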

Compound 4, half-maximal inhibitory concentration: > 128000 nM
Compound 4 ended at the assay's limit (the forecaster's own chance of this, stated with the estimate: 85%); the middle value lies beyond the limit too.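

In this assay compound 4 gives > 128000 nM as a limit and not a number. Its steps to compound 1, compound 2 and compound 3 therefore cannot be read, since all four compounds sit at the same limit: the limit of > 128000 nM in this assay, at which 4 of the 4 values shown sit. The compounds shown leave open whether any aryl group at this place gives a readable value in this assay and how these four compounds compare.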